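Hydroxyalkyl Naphthalenes: Inhibition in the Rat at One Dose

The source may report more compounds than this note shows. Statements on the series, on what has been measured and on what is new or still open speak of the compounds shown alone.

Measured so far:
compound 1 `COc1ccc2cc(CC(C)C(C)=O)ccc2c1` — 7%
compound 2 `COc1ccc2cc(CCC(C)(C)O)ccc2c1` — 3%

Going by the values given here, in a functional assay on the whole organism (strain Wistar) for inhibition, with Rattus norvegicus as the target, with a stated time of 5 days, at a dose of 50 mg/kg by the oral route (on this read-out lower numbers stand for less inhibition and higher numbers for more inhibition at the one dose given (going by the name of the read-out)), compound 2 gives 3%, and the only comparison is the step of a number 4 percentage points lower from compound 1 to compound 2 (within the scatter). Compound 3 `COc1ccc2cc(CCC(C)O)ccc2c1` differs from compound 2 by hydrogen in place of methyl on a saturated chain carbon bound to an oxygen on a saturated carbon and two saturated chain carbons. Among the compounds with values here, no measured step bears directly on this change; the one step in this assay from compound 1 to compound 2 stays within the scatter, and both measured numbers sit low. No step beyond the scatter is therefore expected; the estimated step for compound 3 is a number 1 percentage points higher from compound 2 to compound 3 (within the scatter). The expected value for compound 3 in this assay is 4%, within a range from -6% to 14%.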

Compound 3, a percentage reported as inhibition, in the whole organism at one dose (the size of the read-out at that dose, not a potency): 32%
The estimate for compound 3 lay 28 percentage points below the measured number; the measured number lies above the stated range.
By their numbers in this assay, from the lowest: compounds 2 and 1 (each within the scatter of the next); then compound 3.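

In this assay, going by these compounds alone, the change from 3-hydroxy-3-methylbutyl to 3-hydroxybutyl gives a number 29 percentage points higher from compound 2 to compound 3 (beyond the scatter), the first step beyond the scatter, so the number responds to this single methyl on the carbon bearing the oxygen. The 2-hydroxypropyl chain also stands clear of the 1-acetylethyl chain, with a number 25 percentage points higher from compound 1 to compound 3 (beyond the scatter) as the step. Nothing available bears on the reason for either step.

From the compounds shown here alone, whether an amine or a carboxylic acid in place of the hydroxy group would hold this number remains open. So does the effect of a longer chain.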